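Swapping an aryl group for a short chain on the triazole

This account rests on a few compounds, and the source may have more. Where it says the series, first, only, none or still open, it means among the compounds named here.

Values in a functional assay on A549 cells (Homo sapiens) for antiproliferative activity, read by MTT assay, with a stated time of 72 h; on this read-out higher numbers stand for weaker inhibition and lower numbers for stronger inhibition:
- compound 1 `COc1ccccc1-c1cn(C[C@H](O)[C@H]2OC(=O)C(OCc3ccccc3)=C2OCc2ccccc2)nn1`: > 100000 nM, a limit of the assay
- compound 2 `O=C1O[C@H]([C@@H](O)Cn2cc(CNS(=O)(=O)c3ccc(Cl)cc3)nn2)C(OCc2ccccc2)=C1OCc1ccccc1`: 2870 nM
- compound 3 `Cc1ccc(-c2cn(C[C@H](O)[C@H]3OC(=O)C(OCc4ccccc4)=C3OCc3ccccc3)nn2)cc1`: 8690 nM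

Compound 3, at 8690 nM, has the higher of the two true numbers, so it is the weaker of that pair. The gap between them is a modest 3.0-fold higher number from compound 2 to compound 3 (0.48 log units; beyond the scatter). The entry for compound 1 is a limit and not a true number.

Compound 4 `O=C1O[C@H]([C@@H](O)Cn2cc(CCO)nn2)C(OCc2ccccc2)=C1OCc1ccccc1` carries one change: 2-hydroxyethyl in place of 4-methylphenyl on an aromatic carbon. All measured steps act at this same aromatic carbon. Two are large, an at least 34-fold lower number from compound 1 to compound 2 (1.54 log units; beyond the scatter) and an at least 11-fold lower number from compound 1 to compound 3 (1.06 log units; beyond the scatter), so this place clearly matters in this assay. Those steps also run in different directions from group to group, and none tests a small chain without a ring, so the forecast is loose. Judging from the modest 3.0-fold higher number from compound 2 to compound 3 (0.48 log units; beyond the scatter), a modest rise seems the likeliest outcome. The estimate is a 2.3-fold higher number from compound 3 to compound 4 (0.36 log units; beyond the scatter). Compound 4 is expected at 20000 nM, with an estimated range of 4000 nM to 100000 nM.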

Compound 4, half-maximal inhibitory concentration: > 100000 nM
Compound 4 gave a limit, no number; the forecaster's own chance of this, stated with the estimate: 25%; middle value at least 5.0-fold (0.69 log units) from the limit.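

In this assay, going by these compounds alone, compound 4 is the only one here whose group on this aromatic carbon has no ring, and that change weakens activity far more than the swap between the two ring-bearing groups of compound 2 and compound 3 did: an at least 11-fold higher number from compound 3 to compound 4 (1.06 log units; beyond the scatter). The gap to the sulfonamide-bearing compound is just as clear, with an at least 34-fold higher number from compound 2 to compound 4 (1.54 log units; beyond the scatter), so the short 2-hydroxyethyl chain replaces neither of the active groups. A ring in this group is not enough on its own, though, as compound 1, with 2-methoxyphenyl, also gives a limit, like compound 4, and the step between those two cannot be read: the limit of > 100000 nM in this assay, at which 2 of the 4 values shown sit.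

The compounds shown leave open whether the missing ring or the chain's hydroxyl matters more, which a plain ethyl group or a longer chain ending in an amine could help separate. An unsubstituted phenyl group would also show how much the methyl of compound 3 contributes.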